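This account rests on a few compounds, and the source may have more. Where it says the series, first, only, none or still open, it means among the compounds named here.

compound 1 `COc1ccc2c(=O)cc(C)[nH]c2c1` gives 1.2 in a physicochemical assay for lipophilicity, at pH 7.4; a higher number here means a more lipophilic compound, a lower number a more polar compound
compound 2 `CCCCCCC/C=C/c1c(C)[nH]c2ccccc2c1=O` gives 4.26 in this assay

Compound 2 at 4.26 is the higher of the two numbers, and its gap to compound 1 lies beyond the scatter of repeated measurements.

Compound 3 `Cc1[nH]c2ccccc2c(=O)c1/C=C/C(=O)OC(C)(C)C` has not been measured yet. The structural change from compound 2 is tert-butoxycarbonyl in place of heptyl on a double-bonded chain carbon bound to a double-bonded chain carbon with tert-butoxycarbonyl in place of heptyl on a double-bonded chain carbon bound to a double-bonded chain carbon.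

Among the compounds with values here, no measured pair shows this change, so its size cannot be calibrated. A fall beyond the scatter is expected, with an estimated step of a number 1.46 log units lower from compound 2 to compound 3 (beyond the scatter) in this assay for this change. Within the data shown here, the only lower reference is compound 1 at 1.2 and the estimate stays above it. For compound 3 the expected value is 2.8 with an estimated range from 2.2 to 3.4 in this measurement.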

Compound 3, distribution coefficient: 2.34
Estimate against measurement, compound 3: 0.46 log units above; the measured number falls inside the stated range.
By their numbers in this assay, from the lowest: compound 1; then compound 3; then compound 2.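

In this assay, within the data shown here, tert-butoxycarbonyl in place of heptyl on a double-bonded chain carbon bound to a double-bonded chain carbon gives a number 1.92 log units lower from compound 2 to compound 3 (beyond the scatter), the first measured step and a large one. The two groups have the same heavy-atom count, so this step does not come with a change in that count; the printed differences are the oxygen atoms, the hydrogen-bond acceptors and the double bond outside aromatic rings. No measurement here bears on the reason for the size of this step.

One pair cannot separate the contribution of the carbonyl from that of the tert-butyl part of the entering group. A carboxylic acid or a longer chain at this same place would show how far the number in this assay moves with other groups there.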